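This account rests on a few compounds, and the source may have more. Where it says the series, first, only, none or still open, it means among the compounds named here.

Measured so far:
compound 1 `CN(C)CCCNc1c(C(=O)NCc2ccc(F)cc2)nc(Br)c2cccnc12`, in a functional assay on SK-BR-3 cells (Homo sapiens) for cytotoxicity, read by MTT assay, with a stated time of 72 h (a lower number here means a stronger inhibitor, a higher number a weaker inhibitor), compound 1 gives 1000 nM;
compound 2 `N[C@H]1CC[C@H](Nc2c(C(=O)NCc3ccc(Cl)cc3Cl)nc(Br)c3cccnc23)CC1`, in this assay compound 2 gives 6000 nM.

Compound 2 has the higher of these two numbers, and the gap to compound 1 lies beyond the usual scatter. The next compound, compound 3 `N[C@H]1CC[C@H](Nc2c(C(=O)NCc3ccccc3)nc(Br)c3cccnc23)CC1`, is yet to be measured in this assay. Its change from compound 2 is phenyl in place of 2,4-dichlorophenyl on a saturated chain carbon bound to an amide-type nitrogen. Among the measured compounds shown here, no measured pair shows this change, so the expectation rests on the two values alone. A small step, at most around the edge of the scatter and if anything toward a higher number, is expected, a 1.3-fold higher number from compound 2 to compound 3 (0.12 log units; within the scatter). Compound 3 is therefore estimated at 8000 nM, with a range from 3000 nM to 25000 nM.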

Compound 3, half-maximal inhibitory concentration: 8000 nM
Estimate against measurement, compound 3: no gap at the digits printed; measured number inside the range.
By their numbers in this assay, from the lowest: compound 1; then compounds 2 and 3 (each within the scatter of the next).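

In this assay, taking away the two chlorine atoms of the 2,4-dichlorophenyl group leaves a phenyl and gives a 1.3-fold higher number from compound 2 to compound 3 (0.12 log units; within the scatter), a step within the scatter. Among the compounds shown here, this is the first pair differing in one place, and it shows no measurable effect of these chlorines at this position, on a saturated chain carbon bound to an amide-type nitrogen. Nothing available explains this result.

On these data alone, it remains open whether a methoxy group or an amine on this phenyl would shift the number beyond the scatter. Compound 1 differs from compound 2 in more than one place, so its lower number cannot be assigned to either change.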